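The source may report more compounds than this note shows. Statements on the series, on what has been measured and on what is new or still open speak of the compounds shown alone.

Of the compounds shown here, three have so far been measured in a physicochemical assay for solubility, in phosphate buffer, measured as kinetic solubility, with a stated time of 1 h, at pH 7.4; on this read-out lower numbers stand for lower solubility and higher numbers for higher solubility. Compound 1 `Cc1cc(C)cc(NC(=O)COc2cc(C)nc3ccccc23)c1` gives 55000 nM, compound 2 `COc1ccc2nc(C)cc(OCCNc3cc(C)cc(C)c3)c2c1` gives 33000 nM, and compound 3 `COc1ccc2nc(C)cc(OCC(=O)Nc3cccc(C)c3)c2c1` gives 193000 nM. Compound 3 thus stands highest of the three in this assay, and its gap to compound 1 as well as its gap to compound 2 lies beyond the usual scatter. Compound 4 `COc1ccc2nc(C)cc(OCC(=O)Nc3ccc(F)cc3)c2c1` has not yet been measured. It differs from compound 3 in a single place: 4-fluorophenyl in place of 3-methylphenyl on an amide-type nitrogen. Among the measured compounds shown here, no measured pair in this set carries that same change, so the size of the step is open; the expected step is a 1.3-fold lower number from compound 3 to compound 4 (0.11 log units; within the scatter), no further than the scatter. For compound 4 in this assay the estimate is 150000 nM, with a range from 50000 nM to 400000 nM.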

Compound 4, solubility: 104000 nM
For compound 4 the middle estimate is 1.4-fold (0.16 log units) above the measured one; measured number inside the range.
By their numbers in this assay, from the lowest: compounds 2, 1, 4 and 3 (each within the scatter of the next, the first and the last beyond it).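

In this assay, putting 4-fluorophenyl in place of 3-methylphenyl on an amide-type nitrogen gives a 1.9-fold lower number from compound 3 to compound 4 (0.27 log units; within the scatter) as the first step read at this position. This position therefore takes this exchange with no shift clear of the scatter, although this single pair cannot separate the change of group from the change of place on the ring. Nothing at hand offers an explanation for this result.

As far as these compounds go, whether an amine or a carboxylic acid in place of the 4-fluorophenyl would give a step beyond the scatter remains open. So does the reading for a longer chain on that nitrogen.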